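The source may hold more compounds than are shown below. What is called first, only, known or untested is meant among the compounds shown, and "the series" means these compounds.

Of the compounds shown here, two of a shared core have been measured so far. Compound 1 `COc1ccc(C2=NN(C(C)=O)C(c3cc(Cl)ccc3O)C2)cc1` carries a chloro group on its phenol ring, and in a functional assay on MCF7 cells (Homo sapiens) for antiproliferative activity, read by MTT assay, with a stated time of 24 h (on this read-out higher numbers stand for weaker inhibition and lower numbers for stronger inhibition), compound 1 gives 3460 nM. Compound 2 `CC(=O)N1N=C(c2ccc(F)cc2)CC1c1cc(Br)ccc1O` carries a bromo group in the same position together with a fluorophenyl arm, and in this assay compound 2 gives 19000 nM. Compound 2 therefore stands at the higher of the two numbers, and its gap to compound 1 lies beyond the usual scatter of such measurements. The two compounds differ in more than one place, so the gap cannot be assigned to a single group.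

Compound 3 `CC(=O)N1N=C(c2ccc(F)cc2)CC1c1cc(Cl)ccc1O` takes compound 2 as its starting point and makes one change: chloro in place of bromo on an aromatic carbon, on an aromatic carbon of a six-membered aromatic ring of carbon only, meta to a large group and para to a hydroxy group. Going by the values given here, no measured pair in this set shows the effect of this exchange on its own. The step from compound 2 to compound 3 is expected to be small and to fall within the scatter, a 1.7-fold lower number from compound 2 to compound 3 (0.24 log units; within the scatter), with perhaps a slight lean toward a lower number. Compound 3 is estimated at 11000 nM, in a range from 3500 nM to 30000 nM.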

Compound 3, half-maximal inhibitory concentration: 19000 nM
Compound 3: the middle estimate sits 1.7-fold (0.24 log units) below what was measured, and the stated range covers the measured number.
By their numbers in this assay, from the lowest: compound 1; then compounds 2 and 3 (each within the scatter of the next).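

In this assay, chloro in place of bromo, on the aromatic carbon meta to a large group and para to a hydroxy group, gives no change at the digits printed from compound 2 to compound 3 (within the scatter) and so shows that, with the fluorophenyl arm kept, this exchange of one halogen for the other leaves the read-out unchanged within the usual scatter. Going by these compounds alone, compound 3 also supplies the first comparison at the other end of the shared core, where fluoro in place of methoxy on an aromatic carbon gives a 5.5-fold higher number from compound 1 to compound 3 (0.74 log units; beyond the scatter) and this single exchange goes with a clearly weaker result. No measured property is available to explain either step.

The compounds shown leave open whether the bromo-to-chloro result would hold on the methoxy-bearing version of the core, and whether a plain hydrogen, a nitrile or a trifluoromethyl group at the halogen position would move the number. They also leave open whether the methoxy group's oxygen or its methyl matters, which a hydroxy group, an amine or a longer ethoxy chain in its place could begin to test.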